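The source may hold more compounds than are shown below. What is called first, only, known or untested is meant among the compounds shown, and "the series" means these compounds.

Compound 1 `CO[C@H]1CC[C@H](NC(=O)c2n[nH]cc2NC(=O)c2ncoc2-c2ccccc2)CC1` in an ADME assay on MRC5 cells (Homo sapiens) for inhibition, with a stated time of 72 h (a lower number here means that less compound is needed, a higher number that more compound is needed for the effect), gives 28000 nM. Compound 3 `CO[C@H]1CC[C@H](NC(=O)c2n[nH]cc2NC(=O)c2cc(Cl)cc(Cl)c2)CC1`, an amide built on the same shared core, gives in this assay a value of 13000 nM. Compound 2 `COc1cccc(OC)c1C(=O)Nc1c[nH]nc1C(=O)O` carries a carboxy group in place of such an amide, and in this assay compound 2 reaches only a limit of the assay, > 50000 nM. That limit is the one given as the limit of > 50000 nM in this assay, at which 1 of the 3 values shown sits, so for compound 2 the data hold no number, only a bound. Compound 4 `COCCNC(=O)c1n[nH]cc1NC(=O)c1c(OC)cccc1OC` is the amide of compound 2, differing from it by (2-methoxyethyl)amino in place of hydroxy on a carbonyl carbon. Compound 1, which likewise carries a carboxamide on the shared core, sits inside the measurable range with 28000 nM. Compound 3, which also carries a carboxamide on the shared core, sits inside the measurable range with 13000 nM. Compound 2, by contrast, sits at a limit of the assay. For compound 4 the step is therefore expected to be downward, by an at least 1.6-fold lower number from compound 2 to compound 4 (0.22 log units; that floor lies within the scatter). Compound 4 is accordingly estimated at 30000 nM, with a range from 8000 nM to 100000 nM.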

Compound 4, half-maximal effective concentration: > 50000 nM
Compound 4 ended at the assay's limit; the forecaster's own chance of this, stated with the estimate: 40%; middle value at least 1.6-fold (0.22 log units) away from the limit.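

Compound 2 and compound 4 both stand at the same limit in this assay, so no step can be read between them: the limit of > 50000 nM in this assay, at which 2 of the 4 values shown sit.

Going by these compounds, whether (2-methoxyethyl)amino in place of hydroxy on a carbonyl carbon changes the number in this assay at all, and by how much, stays open.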